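This account rests on a few compounds, and the source may have more. Where it says the series, first, only, none or still open, it means among the compounds named here.

Compound 1 `COc1ccccc1-n1cc(CN2C(=O)C[C@@H]3CC[C@@]2(C)C3(C)C)nn1` gives 110 nM in a functional assay on HepG2 cells (Homo sapiens) for inhibition, read by MTT assay, with a stated time of 24 h (on this read-out lower numbers stand for stronger inhibition and higher numbers for weaker inhibition), the lowest of the two numbers measured. Compound 2 `Cc1ccc(-n2cc(CN3C(=O)C[C@@H]4CC[C@@]3(C)C4(C)C)nn2)cc1` gives 480 nM in this assay, and the step of a 4.4-fold higher number from compound 1 to compound 2 (0.64 log units; beyond the scatter) shows that replacing the 2-methoxyphenyl weakened inhibition modestly. Compound 3 `CC1(C)[C@H]2CC[C@]1(C)N(Cc1cn(-c3cccc(Br)c3)nn1)C(=O)C2` differs from compound 1 by 3-bromophenyl in place of 2-methoxyphenyl on an aromatic nitrogen. Among the compounds with values here, only the step from compound 1 to compound 2 bears on this change, and since it too removed the 2-methoxyphenyl, a similar modest weakening is expected, giving an estimated step of a 3.2-fold higher number from compound 1 to compound 3 (0.50 log units; beyond the scatter). Compound 3 is therefore expected to give about 350 nM in this assay, within 150 nM to 900 nM.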

Compound 3, half-maximal inhibitory concentration: 20 nM
For compound 3 the middle estimate is 18-fold (1.24 log units) above the measured one, outside the stated range (below it).
By their numbers in this assay, from the lowest: compound 3; then compound 1; then compound 2.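

On the aromatic nitrogen of the five-membered ring, replacing 2-methoxyphenyl need not weaken inhibition: 3-bromophenyl gives a 5.5-fold lower number from compound 1 to compound 3 (0.74 log units; beyond the scatter) in this assay and so moves the number the opposite way from 4-methylphenyl. Exchanging 4-methylphenyl for 3-bromophenyl gives a 24-fold lower number from compound 2 to compound 3 (1.38 log units; beyond the scatter) and shows that the choice of substituted phenyl at this position can matter greatly. No measurement shown here explains these differences.

From the compounds shown here alone, compound 3 differs from compound 1 in both the substituent and its place on the phenyl ring, so the contribution of each remains open. Going by these compounds, the effect of an amine or a carboxylic acid on this phenyl ring also remains open.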